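Methyl in Place of Bromo: What to Expect for Compound 3

This account rests on a few compounds, and the source may have more. Where it says the series, first, only, none or still open, it means among the compounds named here.

Compound 1 `Nc1nc(N)nc(-c2ccccc2Br)n1` was tested in a functional assay on the whole organism with Rattus norvegicus as the target, at a dose of 20 mg/kg by the intraperitoneal route (a lower number here means less inhibition, a higher number more inhibition at the dose given (going by the name of the read-out)), where compound 1 gives 26%. Among the two measured compounds this is the lowest number; the nearest is compound 2 `Nc1nc(N)nc(-c2cc(Br)ccc2Br)n1`, which in this assay gives 43%. Within the data shown here, the only measured step, bromo in place of hydrogen on an aromatic carbon, is a number 17 percentage points higher from compound 1 to compound 2 (beyond the scatter).

Compound 3 `Cc1ccccc1-c1nc(N)nc(N)n1` has not yet been measured in this assay. It differs from compound 1 as follows: methyl in place of bromo on an aromatic carbon. Among the measured compounds shown here, no measured step bears directly on this change. The step from compound 1 to compound 2 concerns a second bromo entering at another aromatic carbon while the bromo of compound 1 stays in place; it says nothing about what follows when that bromo leaves and a methyl takes its place. Without a step that speaks to the change, the chemist expects compound 3 to land close to compound 1, and therefore expects a number 4 percentage points lower from compound 1 to compound 3 (within the scatter), which is no step beyond the scatter. In this assay compound 3 is estimated to give 22%, with a range from 5% to 40%.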

Compound 3, a percentage reported as inhibition, in the whole organism at one dose (the size of the read-out at that dose, not a potency): 28%
Compound 3: middle estimate off by 6 percentage points, on the low side, and the stated range covers the measured number.
By their numbers in this assay, from the lowest: compounds 1 and 3 (each within the scatter of the next); then compound 2.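

In this assay, among these compounds, methyl in place of bromo on an aromatic carbon gives a number 2 percentage points higher from compound 1 to compound 3 (within the scatter), and this is the first look at a change of the group on that carbon, ortho to a group of 8 heavy atoms, since compound 1 and compound 2 both carry bromo there. Among the compounds shown here, at the single dose tested, the read-out therefore does not separate bromo from methyl at this position, so the presence of bromo on that carbon is not required for a read-out of this size, whereas the only step beyond the scatter so far came from adding a bromo at another aromatic carbon. No measured information is available to explain this result.

The compounds shown leave open whether a group of a different kind on the same carbon, such as an amine, a carboxylic acid or a longer chain like propyl, would also stay within the scatter of compound 1 or would move the read-out beyond it. They also leave open whether methyl on this carbon, combined with the additional bromo of compound 2, would give the same step that the additional bromo gave alongside the original bromo.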